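Acid ceramidase series: a 4-methoxyphenyl extension

This account rests on a few compounds, and the source may have more. Where it says the series, first, only, none or still open, it means among the compounds named here.

Measured so far:
compound 1 `O=C(NCCCCc1ccccc1)n1c(=O)oc2ccccc21`: 64 nM
compound 2 `Cc1ccc2c(c1)oc(=O)n2C(=O)NCCCCc1ccccc1`: 66 nM
compound 3 `O=C(NCCCCc1ccccc1)n1c(=O)oc2cccc(Br)c21`: no result reported

In an assay on HEK293 cells for inhibition of acid ceramidase (Homo sapiens), with a stated time of 10 min (on this read-out higher numbers stand for weaker inhibition and lower numbers for stronger inhibition), compound 1 gives 64 nM, the lower of the two numbers, and compound 2 gives 66 nM, within the scatter of it. Compound 3 has no number in this assay. Compound 4 `COc1ccc(-c2ccc3oc(=O)n(C(=O)NCCCCc4ccccc4)c3c2)cc1` differs from compound 1 by 4-methoxyphenyl in place of hydrogen on an aromatic carbon. Going by the values given here, the only single-point step available, a 1.0-fold higher number from compound 1 to compound 2 (0.01 log units; within the scatter), bears on this change, since it also alters an aromatic carbon of the shared core, and it lay within the scatter. Among the compounds with values here, no measured compound carries a group as large as 4-methoxyphenyl, so the precedent is weak and the range must be wide. The expected step is therefore a 1.3-fold higher number from compound 1 to compound 4 (0.10 log units; within the scatter). Compound 4 is estimated at 80 nM, between 20 nM and 400 nM.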

Compound 4, half-maximal inhibitory concentration: 67 nM
Estimate against measurement, compound 4: 1.2-fold (0.08 log units) above; the measured number falls inside the stated range.
By their numbers in this assay, from the lowest: compounds 1, 2 and 4 (each within the scatter of the next).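

In this assay, the step at this aromatic carbon of the shared core is a 1.0-fold higher number from compound 1 to compound 4 (0.02 log units; within the scatter), so the earlier result for a methyl group does not mark the limit of what the core can carry without leaving the scatter. Here, the entering 4-methoxyphenyl brings 8 heavy atoms and a six-membered aromatic ring. No measurement shown explains why the number holds.

Open, on these data alone, is whether unsubstituted phenyl, or a carboxylic acid or an amine on the same carbon, would also stay within the scatter of compound 1. The role of the methoxy group also remains unresolved.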